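Adding a hydroxy group to the cyclohexyl ring of compound 1

The source may hold more compounds than are shown below. What is called first, only, known or untested is meant among the compounds shown, and "the series" means these compounds.

Among the compounds with values here, compound 1, with the structure `O=C(NCCCOc1ccc2nc(O)ccc2c1)N(C1CCCCC1)C1CC1`, is tested in a functional assay on the whole organism for inhibition, with Mus musculus as the target, at a dose of 30 mg/kg by the oral route (a higher number here means more inhibition at the dose given (going by the name of the read-out), a lower number less inhibition), where compound 1 gives 100%, the higher of the two numbers measured so far. Compound 2, built as `O=C(NCCCOc1ccc2nc(O)ccc2c1)N(C1CCCCC1)[C@H]1CCCC[C@@H]1O`, carries a 2-hydroxycyclohexyl group where compound 1 has cyclopropyl, and in this assay compound 2 gives 57%. That single step, a number 43 percentage points lower from compound 1 to compound 2 (beyond the scatter), is the only measured one, and it shows that bringing a hydroxy-bearing ring onto the amide-type nitrogen can cost a large share of the inhibition. Compound 3, with the structure `O=C(NCCCOc1ccc2nc(O)ccc2c1)N(C1CC1)[C@H]1CC[C@H](O)CC1`, differs from compound 1 by hydroxy in place of hydrogen on a saturated ring carbon, so the cyclopropyl stays and only the cyclohexyl is changed. The measured step concerns a different change, so it bears on compound 3 only loosely. For compound 3 a moderate loss is expected, a number 25 percentage points lower from compound 1 to compound 3 (beyond the scatter), with the estimate for compound 3 in this assay at 75%, ranging from 40% to 100%.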

Compound 3, a percentage reported as inhibition, in the whole organism at one dose (the size of the read-out at that dose, not a potency): 0%
For compound 3 the middle estimate is 75 percentage points above the measured one; the measured number lies below the stated range.
By their numbers in this assay, from the lowest: compound 3; then compound 2; then compound 1.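

Placing hydroxy on the cyclohexyl ring, three ring bonds from the ring atom that bears a large group, gives a number 100 percentage points lower from compound 1 to compound 3 (beyond the scatter) in this assay. This is the first step shown that changes only the cyclohexyl ring and keeps the cyclopropyl, and it shows that this single change, cyclohexyl to 4-hydroxycyclohexyl, is enough to take compound 3 down to 0% at the dose given. Nothing available explains why the inhibition disappears.

As far as these compounds go, it remains open whether this loss is specific to hydroxy or would also follow from another group on the same ring carbon, such as methoxy, an amine or a carboxylic acid. Also open, from the compounds shown here alone, is how the other spatial arrangement of the 4-hydroxycyclohexyl group would behave.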